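Phenyl for bromo on the benzopyran hydroxyurea series

The source may hold more compounds than are shown below. What is called first, only, known or untested is meant among the compounds shown, and "the series" means these compounds.

Measured compounds:
compound 1, `CCCCCCOc1ccc2c(c1)C=C(CN(O)C(N)=O)CO2`, 280 nM
compound 2, `NC(=O)N(O)CC1=Cc2cc(Br)ccc2OC1`, 1400 nM

In an assay (Cavia porcellus) for inhibition of Polyunsaturated fatty acid 5-lipoxygenase (Homo sapiens) (a higher number here means a weaker inhibitor, a lower number a stronger inhibitor), compound 2 gives the highest of the two numbers; its nearest neighbour is compound 1, which carries hexyloxy where compound 2 carries bromo. For the measured compounds named here, that single swap is the only step measured so far: a 5.0-fold higher number from compound 1 to compound 2 (0.70 log units; beyond the scatter).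

Compound 3, `NC(=O)N(O)CC1=Cc2cc(-c3ccccc3)ccc2OC1`, has not been measured. It differs from compound 2 by phenyl in place of bromo on an aromatic carbon. Going by the values given here, no measured step covers a phenyl at this position; the one step that bears on it shows that exchanging bromo for a larger group at this carbon gave a modest drop in the number. By analogy, a modest drop beyond the scatter is expected for compound 3 in this assay, a 2.8-fold lower number from compound 2 to compound 3 (0.45 log units; beyond the scatter). Compound 3 is therefore estimated at 500 nM, in the range 150 nM to 1800 nM.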

Compound 3, half-maximal inhibitory concentration: 240 nM
Estimate against measurement, compound 3: 2.1-fold (0.32 log units) above; the range from low to high includes it.
By their numbers in this assay, from the lowest: compounds 3 and 1 (each within the scatter of the next); then compound 2.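

In this assay, phenyl in place of bromo on this aromatic carbon gives a 5.8-fold lower number from compound 2 to compound 3 (0.77 log units; beyond the scatter) and so shows that the lower number seen with hexyloxy is not tied to that chain: an aromatic ring of carbon only at the same carbon also goes with it. Between the two larger groups the assay draws no distinction, with a 1.2-fold lower number from compound 1 to compound 3 (0.07 log units; within the scatter), so an open chain and a six-membered aromatic ring serve alike here. Nothing available explains why either group gives a lower number than bromo.

Open, as far as these compounds go, is whether a phenyl carrying a further group, such as fluoro or methoxy, would keep this number, and whether a pyridine ring or a benzyl group would do the same. Also open, from the compounds shown here alone, is how a shorter chain such as methoxy or plain hydrogen at this carbon would compare.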